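A few compounds are considered here, and "the series" means these few. Any claim that something is new, unique, unknown or untested is made for them only; others in the source may bear on it.

Measured so far, in a functional assay on MOLT-3 cells (Homo sapiens) for antiproliferative activity; a higher number here means a weaker inhibitor, a lower number a stronger inhibitor:
Compound 1 `CSc1nc2c([nH]1)C(=O)C=C(N(C)C)C2=O` gives 18.3 uM.
Compound 2 `CSc1nc2c([nH]1)C(=O)C(Br)=C(Br)C2=O` gives 12 uM.
Compound 3 `CSc1nc2c([nH]1)C(=O)C=C(Br)C2=O` gives 32.1 uM.

All three share one core and differ only in what sits on the six-membered non-aromatic ring of carbon only. Compound 3 has the highest number of the three: the step of a 1.8-fold higher number from compound 1 to compound 3 (0.24 log units; within the scatter) is within the scatter, so compound 1 and compound 3 cannot be told apart, while the step of a 2.7-fold higher number from compound 2 to compound 3 (0.43 log units; beyond the scatter) is modest but beyond the scatter.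

Compound 4 `COC1=CC(=O)c2[nH]c(SC)nc2C1=O` is not yet measured. It differs from compound 3 in one place: methoxy in place of bromo on a double-bonded ring carbon.

Going by the values given here, two measured steps bear on this change, both at the same kind of position. Swapping dimethylamino for bromo, in the step from compound 1 to compound 3, moved the number only within the scatter; removing bromo altogether, in the step from compound 2 to compound 3, gave a modest rise. Putting methoxy where bromo stood is expected, on this basis, to change the number little, if anything towards a slightly lower value, that is a step of a 1.5-fold lower number from compound 3 to compound 4 (0.16 log units; within the scatter).

Compound 4 is therefore estimated at 22 uM in this assay, with a likely range from 9 uM to 55 uM.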

Compound 4, concentration for 50% inhibition: 20.8 uM
Compound 4: the middle estimate sits 1.1-fold (0.02 log units) above what was measured; low and high end bracket the measured number.
By their numbers in this assay, from the lowest: compounds 2, 1, 4 and 3 (each within the scatter of the next, the first and the last beyond it).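

In this assay, methoxy in place of bromo on a double-bonded ring carbon gives a 1.5-fold lower number from compound 3 to compound 4 (0.19 log units; within the scatter), and methoxy in place of dimethylamino gives a 1.1-fold higher number from compound 1 to compound 4 (0.06 log units; within the scatter). Together with the earlier step between compound 1 and compound 3, this closes the set: all three pairs among compound 1, compound 3 and compound 4 lie within the scatter, so bromo, methoxy and dimethylamino cannot be told apart at this position, even though they differ in their atoms and in size. No measurement shown here explains why these three groups give such similar numbers.

On these data alone, it remains open whether a group of another kind at this position, such as a carboxylic acid, a primary amine or a longer chain like butoxy, would move the number beyond the scatter. Also open is whether methoxy would give a similar number in a compound that also carries a bromo on the other double-bonded ring carbon, the one place where a change among these compounds, from compound 2 to compound 3, has so far gone beyond the scatter.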